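Swapping the aryl ether at the ketone end

A few compounds are considered here, and "the series" means these few. Any claim that something is new, unique, unknown or untested is made for them only; others in the source may bear on it.

Compound 2 `CC(C)[C@H](NC(=O)COc1cccc2ccccc12)C(=O)N[C@@H](CC(=O)O)C(=O)COc1ccccc1[N+](=O)[O-]` has no number in a functional assay on Jurkat cells (Homo sapiens); a higher number here means a weaker inhibitor, a lower number a stronger inhibitor: compound 2 gives > 100000 nM, which is a limit of the assay and not a measured value (the limit of > 100000 nM in this assay, at which 1 of the 2 values shown sits). Compound 1 `CC(C)[C@H](NC(=O)COc1cccc2ccccc12)C(=O)N[C@@H](CC(=O)O)C(=O)COc1ccc(Oc2ccc(C(F)(F)F)cc2)cc1` gives 9300 nM in this assay. Compound 3 `CC(C)[C@H](NC(=O)COc1cccc2ccccc12)C(=O)N[C@@H](CC(=O)O)C(=O)COc1cc(F)c(F)cc1F` differs from compound 2 by 2,4,5-trifluorophenyl in place of 2-nitrophenyl on an oxygen on a saturated carbon. Among the compounds with values here, no measured pair shows how large such a change is here, so the expectation is uncertain. The step of an at least 3.3-fold lower number from compound 2 to compound 3 (0.52 log units; beyond the scatter) is expected to move toward a stronger inhibitor, though it might also stay at the limit. Compound 3 is estimated at 30000 nM, with a range from 5000 nM to 150000 nM.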

Compound 3, half-maximal inhibitory concentration: 39300 nM
Compound 3: middle estimate off by 1.3-fold (0.12 log units), on the low side, within the range that was stated.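

The change from 2-nitrophenyl to 2,4,5-trifluorophenyl gives an at least 2.5-fold lower number from compound 2 to compound 3 (0.40 log units; beyond the scatter) in this assay. Within the data shown here, the two groups have the same heavy-atom count, so a measurable number at this position does not require a group as large as the one in compound 1. Compound 2 stands at a limit of the assay, so this step gives only a minimum size: the limit of > 100000 nM in this assay, at which 1 of the 3 values shown sits.

On these data alone, it remains open how much each fluorine contributes. A plain phenyl or a 2-fluorophenyl on this oxygen could help separate their contributions.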